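Chain shortening at the ring nitrogen in a coumarin-fused series

A few compounds are considered here, and "the series" means these few. Any claim that something is new, unique, unknown or untested is made for them only; others in the source may bear on it.

Measured compounds:
- compound 1, `CCCn1nc(C)c2c(C)cc(=O)oc21`, a functional assay on the whole organism with Mus musculus as the target, in the writhing test; a lower number here means that less compound is needed, a higher number that more compound is needed for the effect: 54.3 mg/kg
- compound 2, `CCn1nc(C)c2c(C)cc(=O)oc21`, 24.9 mg/kg
- compound 3, `CCn1nc2oc(=O)cc(C)c2c1C`, 14.6 mg/kg

Compound 1 and compound 2 share one core and differ by hydrogen in place of methyl on a saturated chain carbon, two bonds along the chain from an aromatic nitrogen. The step of a 2.2-fold lower number from compound 1 to compound 2 (0.34 log units; beyond the scatter) is the only one measured for this kind of change. Compound 3 carries a different core; the difference between the two cores is not broken down here. Compound 3 and compound 2 lie within the scatter of each other, while compound 3 against compound 1 is clearly apart.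

Compound 4, `Cc1cc(=O)oc2nn(C)c(C)c12`, is not yet measured. It differs from compound 3 by hydrogen in place of methyl on a saturated chain carbon bound to an aromatic nitrogen. This is the same kind of change as from compound 1 to compound 2, though not the same: there the place was a saturated chain carbon two bonds along the chain from an aromatic nitrogen, here it is a saturated chain carbon bound to an aromatic nitrogen, and the cores differ.

Within the data shown here, compound 4 is expected to show a 1.6-fold lower number from compound 3 to compound 4 (0.21 log units; within the scatter), a step of similar direction to the one seen, because a 2.2-fold lower number from compound 1 to compound 2 (0.34 log units; beyond the scatter) is the only guide, with wider uncertainty for the changed core and place. The estimate for compound 4 is 9 mg/kg, within 4 mg/kg to 25 mg/kg.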

Compound 4, dose for half-maximal effect: 6.09 mg/kg
Compound 4: the middle estimate sits 1.5-fold (0.17 log units) above what was measured; the range from low to high includes it.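

In this assay, going from ethyl to methyl on the core of compound 3 gives a 2.4-fold lower number from compound 3 to compound 4 (0.38 log units; beyond the scatter). Set beside the earlier chain shortening on the core of compound 1, the change carries over from one core to the other in direction and in size: the same change on two cores in this assay, a 2.2-fold lower number (0.34 log units; beyond the scatter) from compound 1 to compound 2 and a 2.4-fold lower number (0.38 log units; beyond the scatter) from compound 3 to compound 4, 1.1-fold (0.04 log units) apart, within the scatter of two such steps. This is one pair on each core, and the place differs as well as the core, with the earlier change two bonds along the chain from an aromatic nitrogen and the new one on a saturated chain carbon bound to an aromatic nitrogen, so the agreement shows no general rule for the series and does not separate the part played by core from that played by place.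

The compounds shown leave open how methyl on the aromatic nitrogen behaves on the core of compound 1, and whether hydrogen in that place continues the run of lower numbers. Also open, on these data alone, is whether a branched chain such as isopropyl, or a chain ending in an amine or a carboxylic acid, would fit the same line.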